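The source may report more compounds than this note shows. Statements on the series, on what has been measured and on what is new or still open speak of the compounds shown alone.

Measured compounds:
- compound 1 `CC(C)(C)OC(=O)CCC[N+]1(C)CCc2c(sc(NC(=O)Nc3ccc(Cl)cc3)c2C(N)=O)C1` — 250 nM
- compound 2 `CCC(C)(C)C1CCc2c(sc(NC(=O)Nc3ccc(Cl)cc3)c2C(N)=O)C1` — > 25000 nM

Among the measured compounds shown here, in a functional assay (strain AB) with Danio rerio as the target, read by microscopy, with a stated time of 1 h (a lower number here means that less compound is needed, a higher number that more compound is needed for the effect), compound 1 gives 250 nM, the only numeric value in this set. Compound 2 gives > 25000 nM, which is a limit of this assay and not a number; it matches (the limit of > 25000 nM in this assay, at which 1 of the 2 values shown sits). For the measured compounds named here, compound 2 differs from compound 1 in more than one place, so no single step connects them, and their values show only that compound 1 sits at a measured concentration while compound 2 sits at the limit.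

Compound 3 `CC(C)[N+]1(C)CCc2c(sc(NC(=O)Nc3ccc(Cl)cc3)c2C(N)=O)C1` has not yet been measured. It differs from compound 1 in one place (isopropyl in place of 3-(tert-butoxycarbonyl)propyl on an amine nitrogen in a ring). The charged ring nitrogen and the rest of the shared core are kept.

Going by the values given here, no measured step of this kind is available. A modest loss is expected, of about a 2.4-fold higher number from compound 1 to compound 3 (0.38 log units; beyond the scatter), though a result within the scatter would not be surprising. Compound 3 is expected at 600 nM, in the range 150 nM to 3000 nM.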

Compound 3, half-maximal effective concentration: 960 nM
Beside the measured number, compound 3's estimate is 1.6-fold (0.20 log units) below it; the measured number falls inside the stated range.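

Among the compounds shown here, the first single-place step at this amine nitrogen in a ring reads, in this assay, a 3.8-fold higher number from compound 1 to compound 3 (0.58 log units; beyond the scatter). The 3-(tert-butoxycarbonyl)propyl group is therefore not needed for a measured number at this position: with isopropyl on the charged ring nitrogen, compound 3 still gives 960 nM, although the larger group gives the lower number. Nothing measured here bears on the reason for the size of this step.

From the compounds shown here alone, it remains open whether the step follows the size of the group or the carbonyl-bearing end of the chain; a methyl group, a propyl chain ending in a carboxylic acid or a longer alkyl chain on this nitrogen would help to separate the two. Going by these compounds, compound 2 differs from compound 1 in more than one place, so the contribution of the charged ring nitrogen also stays open.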